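Aryl exchange on the sulfonyl: expected tolerance of compound 3

The compounds below may be only part of what the source reports. "The series", "measured", "known", "first", "only" and "open" are said of these compounds alone.

Compound 1 `N#CCCN(Cc1ccco1)S(=O)(=O)c1ccc(Br)cc1` stands only at a limit. In an ADME assay on MDCK cells (Canis lupus familiaris) for cytotoxicity, read by MTT assay, with a stated time of 24 h (a higher number here means that more compound is tolerated, a lower number that less compound is tolerated), compound 1 gives > 180000 nM, which is a limit of the assay and not a number. Compound 2 `COc1ccc(S(=O)(=O)N(CCC#N)Cc2ccco2)cc1` likewise returns only a limit. In this assay compound 2 gives > 208000 nM, again a limit. Going by the values given here, the single measured step, a step that the two limits leave unreadable from compound 1 to compound 2, therefore has no readable size, because the limit of > 180000 nM in this assay, at which 1 of the 2 values shown sits, is a limit. The same holds at the other end, because the limit of > 208000 nM in this assay, at which 1 of the 2 values shown sits, is also a limit.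

Compound 3 `Cc1cccc(S(=O)(=O)N(CCC#N)Cc2ccco2)c1` differs from compound 1 by 3-methylphenyl in place of 4-bromophenyl on a sulfonyl sulfur. Among the compounds with values here, only the step from compound 1 to compound 2 bears on an exchange at this position, and all it shows is that a change at the aryl group did not bring the value down to a readable number. No step beyond the scatter is expected for compound 3 in this assay, so the expected step that the limit leaves unreadable from compound 1 to compound 3 is close to zero. Compound 3 is estimated at 200000 nM, with an expected range from 60000 nM to 600000 nM, and is likely to be reported as a limit once more.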

Compound 3, half-maximal cytotoxic concentration: > 219000 nM
Compound 3: a limit, no number (the forecaster's own chance of this, stated with the estimate: 75%); middle value at least 1.0-fold (0.03 log units) away from the limit.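

In this assay compound 3 gives > 219000 nM, a limit of the assay and not a number. Compound 1 also stands only at a limit, so the step between compound 1 and compound 3 cannot be read. The compounds shown leave open what half-maximal cytotoxic concentration compound 1, compound 2 or compound 3 would reach as a number, and whether the aryl exchange changes it.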